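Ester Side Chain Swapped for a Small Hydroxybutyl Ether

The compounds below may be only part of what the source reports. "The series", "measured", "known", "first", "only" and "open" are said of these compounds alone.

Compound 1 `CC(C)=CC[C@@H](OC[C@H](C)O)C1=CC(=O)c2c(O)ccc(O)c2C1=O` and compound 2 `CCCCC(C)(O)CC(=O)O[C@H](CC=C(C)C)C1=CC(=O)c2c(O)ccc(O)c2C1=O` share the same core and differ in one side group. In a functional assay on HeLa cells (Homo sapiens) for cytotoxicity, read by MTT assay (on this read-out higher numbers stand for weaker inhibition and lower numbers for stronger inhibition), compound 1 gives 40300 nM, while compound 2 gives 60600 nM. Among the measured compounds shown here, the only measured step, a 1.5-fold higher number from compound 1 to compound 2 (0.18 log units; within the scatter), put (2-hydroxy-2-methylhexyl)carbonyl in place of 2-hydroxypropyl on an oxygen on a saturated carbon; compound 2 and compound 1 thus sit within the scatter of each other, so neither can be called weaker or stronger. Compound 3 `CCC(O)CO[C@H](CC=C(C)C)C1=CC(=O)c2c(O)ccc(O)c2C1=O` is not yet measured and differs from compound 2 by 2-hydroxybutyl in place of (2-hydroxy-2-methylhexyl)carbonyl on an oxygen on a saturated carbon. This brings back a short hydroxyalkyl chain much like that of compound 1, and since the step from compound 1 to compound 2 stayed within the scatter, the expected step of a 1.4-fold lower number from compound 2 to compound 3 (0.16 log units; within the scatter) is likewise small. Compound 3 is expected to give 42000 nM, within a range from 20000 nM to 90000 nM.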

Compound 3, half-maximal inhibitory concentration: 28700 nM
For compound 3 the middle estimate is 1.5-fold (0.17 log units) above the measured one, and the stated range covers the measured number.
By their numbers in this assay, from the lowest: compounds 3, 1 and 2 (each within the scatter of the next, the first and the last beyond it).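

In this assay, among the compounds shown here, putting 2-hydroxybutyl, with 5 heavy atoms, in place of (2-hydroxy-2-methylhexyl)carbonyl on this oxygen gives a 2.1-fold lower number from compound 2 to compound 3 (0.32 log units; beyond the scatter) and is the first step here to pass the scatter, though only modestly. Within the short hydroxyalkyl ethers, the change from compound 1 to compound 3, 1-hydroxypropyl in place of 1-hydroxyethyl, gives a 1.4-fold lower number from compound 1 to compound 3 (0.15 log units; within the scatter) and so cannot be told apart from no change. No measurement offered here explains the step away from compound 2.

Going by these compounds, that step changes the carbonyl and the chain together, so it remains open which of the two matters. Also open, on these data alone, is how this position would respond to an amine or a carboxylic acid at the end of the chain, or to a longer ether chain.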